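A Smaller Saturated Ring on the Shared Core

A few compounds are considered here, and "the series" means these few. Any claim that something is new, unique, unknown or untested is made for them only; others in the source may bear on it.

Compound 1 `Cc1ccc(Cl)cc1Nc1nc(C(F)(F)F)ccc1CNC(=O)C(C)c1ccc(NS(C)(=O)=O)c(F)c1` was tested in a functional assay on CHO-K1 cells for antagonist activity at transient receptor potential cation channel subfamily V member 1 (Homo sapiens), read by FLIPR (a lower number here means a stronger inhibitor, a higher number a weaker inhibitor), where compound 1 gives 14 nM. Compound 2 `CC(C(=O)NCc1ccc(C(F)(F)F)nc1N1CCC(C(=O)c2ccc(F)cc2)CC1)c1ccc(NS(C)(=O)=O)c(F)c1` gives 3.9 nM in this assay. Of these two numbers, compound 1 has the higher one, so compound 1 is the weaker inhibitor of the pair, and its gap to compound 2 lies beyond the usual scatter of repeated measurements.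

Compound 3 `CC(C(=O)NCc1ccc(C(F)(F)F)nc1N1CCN(C)CC1)c1ccc(NS(C)(=O)=O)c(F)c1` has not yet been measured. Compared with compound 1 the change is 4-methylpiperazin-1-yl in place of (5-chloro-2-methylphenyl)amino on an aromatic carbon. Compound 2 shows that a six-membered non-aromatic ring with nitrogen on the aromatic carbon next to the ring nitrogen can give a strong inhibitor, but that ring in compound 2 carries a far larger substituent than the 4-methylpiperazin-1-yl group entering here. Within the data shown here, no measured pair isolates the present change, so the expectation rests on these two points alone. In this assay compound 3 is expected to be a weaker inhibitor than compound 1, with an expected step of a 4.3-fold higher number from compound 1 to compound 3 (0.63 log units; beyond the scatter) beyond the scatter. The estimate for compound 3 is 60 nM, with a range from 12 nM to 300 nM.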

Compound 3, inhibition constant: 146 nM
Beside the measured number, compound 3's estimate is 2.4-fold (0.39 log units) below it; low and high end bracket the measured number.
By their numbers in this assay, from the lowest: compound 2; then compound 1; then compound 3.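

In this assay, putting 4-methylpiperazin-1-yl in place of (5-chloro-2-methylphenyl)amino on this aromatic carbon, next to the ring nitrogen, costs a large amount of inhibition, a 10-fold higher number from compound 1 to compound 3 (1.02 log units; beyond the scatter), so what this position carries matters greatly. The result also qualifies what compound 2 suggested: compound 2 gives 3.9 nM and compound 3 gives 146 nM, which shows that a six-membered non-aromatic ring with nitrogen at this place does not by itself secure a strong inhibitor. No measurement shown here explains why the step is so large.

The change removes an aromatic ring of carbon only and a hydrogen-bond donor, and it brings in a second ring nitrogen, so the compounds shown cannot say which of these differences accounts for the loss. A plain phenylamino group, a piperidin-1-yl group or a morpholin-4-yl group on the same carbon would help to pull these differences apart, as would a benzoyl group on the piperazine ring.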